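This account rests on a few compounds, and the source may have more. Where it says the series, first, only, none or still open, it means among the compounds named here.

In a physicochemical assay for acid dissociation, compound 3 (`CCCCCCCCS(=O)(=O)c1ccc(O)c(C(=O)Nc2ccc(C(F)(F)F)cc2)c1`) gives 6.2, level with compound 2 (`CCCCS(=O)(=O)c1ccc(O)c(C(=O)Nc2ccc(C(F)(F)F)cc2)c1`) at 6.2. These two share the highest number of the three, while compound 1 (`CCCCCCS(=O)(=O)c1ccc(O)c(C(=O)Nc2ccc(Br)cc2)c1`) gives 5.2. Compound 4 (`CCCCCCS(=O)(=O)c1ccc(O)c(C(=O)Nc2ccc(C(F)(F)F)cc2)c1`) differs from compound 3 by hydrogen in place of ethyl on a saturated chain carbon, six bonds along the chain from a sulfonyl sulfur. Going by the values given here, the one measured step bearing on this is a change on the same chain, butyl in place of hydrogen, which gave no change at the digits printed from compound 2 to compound 3 (within the scatter). On that evidence, no step beyond the scatter is expected in this assay. The expected step is no change at the digits printed from compound 3 to compound 4 (within the scatter). The estimated value for compound 4 is 6.2, with an expected range of 5.9 to 6.5.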

Compound 4, acid dissociation constant: 6.2
Compound 4: middle estimate and measured number agree at the digits printed; the range from low to high includes it.
By their numbers in this assay, from the lowest: compound 1; then compounds 2, 3 and 4 (each within the scatter of the next).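

Chain length on the sulfonyl sulfur, with trifluoromethyl held fixed, leaves this assay flat: the notes record no change at the digits printed from compound 3 to compound 4 (within the scatter) and no change at the digits printed from compound 2 to compound 4 (within the scatter). Going by these compounds alone, compound 4 also connects the chain series to compound 1 at a shared chain, with trifluoromethyl in place of bromo on an aromatic carbon giving a number 1.00 log units higher from compound 1 to compound 4 (beyond the scatter) as the only new step beyond the scatter.

Nothing measured here accounts for these readings. Still open, as far as these compounds go, is whether the flat reading survives an amine or a carboxylic acid at the end of the chain, and how a nitrile in place of trifluoromethyl would read.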